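The source may report more compounds than this note shows. Statements on the series, on what has been measured and on what is new or still open speak of the compounds shown alone.

Compound 2, with the structure `CC(=O)OC[C@H]1O[C@@H](CC(=O)/C=C/c2ccc3ccccc3c2)[C@H](OC(C)=O)[C@@H](OC(C)=O)[C@@H]1OC(C)=O`, carries an aromatic group at the end of its enone chain, and in an ADME assay on cells (Epithelial cell, Homo sapiens) for cytotoxicity, read by MTT assay, with a stated time of 24 h (on this read-out lower numbers stand for higher toxicity in this test and higher numbers for lower toxicity in this test), its entry reads "not determined" (no result reported), so no single number anchors it. Compound 1, `COc1cc(/C=C/C(=O)C[C@@H]2O[C@H](COC(C)=O)[C@@H](OC(C)=O)[C@H](OC(C)=O)[C@H]2OC(C)=O)cc(OC)c1OC`, is in the same position, its entry in this assay being "not determined" (no result reported). Among the measured compounds shown here, the only number in the set belongs to compound 3, `CC(=O)OC[C@H]1O[C@@H](CC(=O)/C=C/c2ccc(Cl)c(Cl)c2)[C@H](OC(C)=O)[C@@H](OC(C)=O)[C@@H]1OC(C)=O`, which in this assay gives 25.8 nM. Compound 4, `CC(=O)OC[C@H]1O[C@@H](CC(=O)/C=C/c2cccnc2)[C@H](OC(C)=O)[C@@H](OC(C)=O)[C@@H]1OC(C)=O`, differs from compound 2 by pyridin-3-yl in place of naphthalen-2-yl on a double-bonded chain carbon bound to a double-bonded chain carbon. Compound 2 has no value of its own, and the size of this step cannot be checked against a measured pair. The expectation, resting on the value of compound 3 at 25.8 nM as the nearest reference, is a step that is small and, if anything, toward higher numbers in this assay, quite possibly within the scatter. On that basis compound 4 is expected to give about 60 nM in this assay, within a range from 10 nM to 400 nM.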

Compound 4, half-maximal cytotoxic concentration: 4.17 nM
Estimate against measurement, compound 4: 14-fold (1.16 log units) above; measured number outside the range, below it.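

In this assay, the aromatic group at the end of the enone chain proves able to shift the read-out: pyridin-3-yl in place of 3,4-dichlorophenyl on a double-bonded chain carbon bound to a double-bonded chain carbon gives a change beyond the usual scatter (a 6.2-fold lower number from compound 3 to compound 4 (0.79 log units; beyond the scatter)). Among the compounds shown here, this is the first measured step in the set, and it shows that a single ring holding one nitrogen can replace the dichlorinated ring at this place with a move toward higher toxicity in this test, while the steps involving compound 1 and compound 2 cannot be read. No measurement here accounts for the shift.

From the compounds shown here alone, whether pyridin-4-yl or plain phenyl at this place would give a similar number remains open. So does the effect of an amine on the pyridin-3-yl group.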